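From compound 3 to compound 4 at the sulfonyl sulfur

The compounds below may be only part of what the source reports. "The series", "measured", "known", "first", "only" and "open" are said of these compounds alone.

Compound 1 `CC1CCN(C2CCN(S(=O)(=O)c3cccnc3Cl)CC2)CC1` gives > 10000 nM as a limit.
Compound 2 `CC1CCN(C2CCN(S(=O)(=O)c3cccnc3)CC2)CC1` gives > 10000 nM as a limit.
Compound 3 `CC1CCN(C2CCN(S(=O)(=O)c3cccnc3F)CC2)CC1` gives > 10000 nM as a limit.

In an ADME assay on HCT-116 cells (Homo sapiens) for cytotoxicity, read by CellTiter-Glo, with a stated time of 72 h (on this read-out higher numbers stand for weaker inhibition and lower numbers for stronger inhibition), compound 3 stands at the limit > 10000 nM and has no number of its own. Within the data shown here, the series so far shows the limit of > 10000 nM in this assay, at which 3 of the 3 values shown sit, and allows no ranking. The change to compound 4 `CC1CCN(C2CCN(S(=O)(=O)c3nccn3C)CC2)CC1` puts 1-methyl-1H-imidazol-2-yl in place of 2-fluoropyridin-3-yl on a sulfonyl sulfur and replaces the whole group. The measured steps that bear on it are a step that the two limits leave unreadable from compound 1 to compound 2 and a step that the two limits leave unreadable from compound 1 to compound 3 and a step that the two limits leave unreadable from compound 2 to compound 3 and each is a change on an aromatic carbon only. With no readable size to carry over, no step beyond the scatter is expected in this assay and another limit is the likely report. The estimated step is a step that the limit leaves unreadable from compound 3 to compound 4 and its size is uncertain. Compound 4 is expected at 15000 nM (range 8000 nM to 30000 nM).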

Compound 4, half-maximal inhibitory concentration: > 10000 nM
Compound 4 was reported as a limit (the forecaster's own chance of this, stated with the estimate: 90%); the middle value does not contradict the limit.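

No step can be read among compound 1, compound 2, compound 3 and compound 4 in this assay, and each reports only a limit: the limit of > 10000 nM in this assay, at which 4 of the 4 values shown sit.

The compounds shown leave open whether any group on the sulfonyl sulfur gives a measurable value.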